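From tert-butylamino to diethylamino on the shared core

A few compounds are considered here, and "the series" means these few. Any claim that something is new, unique, unknown or untested is made for them only; others in the source may bear on it.

Among the measured compounds shown here, in an ADME assay on the whole organism for inhibition, with Oryza sativa as the target, with a stated time of 4 days (on this read-out lower numbers stand for stronger inhibition and higher numbers for weaker inhibition), compound 1 `C[C@H](Nc1nc(Cl)nc(NC(C)(C)C)n1)c1ccccc1` gives the lowest of the three numbers so far, at 3310 nM. Compound 3 `C[C@@H](Nc1nc(Cl)nc(NC(C)(C)C)n1)c1ccccc1` gives 9330 nM, and compound 2 `CCCN(CC)c1nc(Cl)nc(N[C@H](C)c2ccccc2)n1` gives 24500 nM.

Compound 4 `CCN(CC)c1nc(Cl)nc(N[C@@H](C)c2ccccc2)n1` has not yet been measured. It departs from compound 1 in one place: diethylamino in place of (tert-butyl)amino on an aromatic carbon. Diethylamino stands in place of (tert-butyl)amino on an aromatic carbon, between two ring nitrogen atoms.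

For the measured compounds named here, the nearest precedent is the same kind of exchange run the other way, a 2.6-fold lower number from compound 2 to compound 3 (0.42 log units; beyond the scatter), where (tert-butyl)amino replaces ethyl(propyl)amino. Reversed, that step points to a higher number on leaving (tert-butyl)amino. The other measured step, a 2.8-fold higher number from compound 1 to compound 3 (0.45 log units; beyond the scatter), changes only the configuration as drawn, so it says little about this exchange. With a single precedent, a modest rise is expected, estimated as a 2.4-fold higher number from compound 1 to compound 4 (0.38 log units; beyond the scatter). In this assay, compound 4 is expected to give about 8000 nM, with an estimated range from 3000 nM to 20000 nM.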

Compound 4, half-maximal inhibitory concentration: 380 nM
Estimate against measurement, compound 4: 21-fold (1.32 log units) above; the whole stated range lies above it.
By their numbers in this assay, from the lowest: compound 4; then compound 1; then compound 3; then compound 2.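

In this assay, diethylamino in place of (tert-butyl)amino gives an 8.7-fold lower number from compound 1 to compound 4 (0.94 log units; beyond the scatter), so leaving (tert-butyl)amino at this place can lower the number, with the heavy-atom count unchanged and the hydrogen-bond donor gone. Compound 1 and compound 4 share one configuration as drawn, whereas a 2.6-fold lower number from compound 2 to compound 3 (0.42 log units; beyond the scatter) lies on the other configuration and involves ethyl(propyl)amino, so the two steps do not describe the same change. The configuration as drawn can shift this read-out by itself, so steps on the two configurations have to be kept apart: the fact that compounds 1 and 3 differ only in the configuration as drawn.

The compounds shown leave open whether diethylamino also gives a lower number on the other configuration, and whether the loss of the hydrogen-bond donor goes with the drop. Going by these compounds, how pyrrolidine or dimethylamino would read at this place also remains open.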